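Ester chain length and thioester group versus carboxylesterase half-life

The source may report more compounds than this note shows. Statements on the series, on what has been measured and on what is new or still open speak of the compounds shown alone.

Measured compounds:
- compound 1 `CCOC(=O)[C@@H](N)CCC(=O)NCCSC(=O)c1ccccc1` gives 0.167 h in an ADME assay on liver for metabolic stability, with liver carboxylesterase 1 (Homo sapiens) as the target; on this read-out lower numbers stand for a shorter-lived compound and higher numbers for a longer-lived compound
- compound 2 `CCCOC(=O)[C@@H](N)CCC(=O)NCCSC(C)=O` gives 0.167 h in this assay
- compound 3 `CCCOC(=O)[C@@H](N)CCC(=O)NCCSC(=O)c1ccccc1` gives 0.167 h in this assay

Compound 2 stands level with compound 1 and compound 3 at the digits read; all three sit together within the scatter, so no order among them can be stated.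

Compound 4 `CCOC(=O)[C@@H](N)CCC(=O)NCCSC(C)=O` has not yet been measured. It differs from compound 2 by hydrogen in place of methyl on a saturated chain carbon, two bonds along the chain from an oxygen next to a carbonyl group.

Among the measured compounds shown here, two measured steps bear on this change. The step of no change at the digits printed from compound 1 to compound 3 (within the scatter) is the same change run the other way at the same place and stayed flat. The step of no change at the digits printed from compound 2 to compound 3 (within the scatter), at the other end of the molecule, also stayed flat. Nothing among the three measured compounds moves the half-life, so no step beyond the scatter is expected in this assay, in either direction.

For compound 4 the half-life is therefore estimated at 0.167 h, with a range of 0.08 h to 0.35 h. The expected step is no change at the digits printed from compound 2 to compound 4 (within the scatter), resting on the flat step no change at the digits printed from compound 1 to compound 3 (within the scatter).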

Compound 4, half-life in the liver carboxylesterase 1 assay: 0.167 h
Beside the measured number, compound 4's estimate shows no gap at the digits printed, and the stated range covers the measured number.
By their numbers in the liver carboxylesterase 1 assay, from the lowest: compounds 1, 2, 3 and 4 (each within the scatter of the next).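

The propoxy to ethoxy change at this position now reads on a second core in the liver carboxylesterase 1 assay, where compound 2 gives 0.167 h and compound 4 gives 0.167 h, with no change at the digits printed from compound 2 to compound 4 (within the scatter), and the two readings agree: the same change on two cores in the liver carboxylesterase 1 assay, no change at the digits printed (within the scatter) from compound 1 to compound 3 and no change at the digits printed (within the scatter) from compound 4 to compound 2, 1.0-fold (0.00 log units) apart, within the scatter of two such steps

Methyl in place of phenyl on the carbonyl carbon, read with the ethoxy group held, gives no change at the digits printed from compound 1 to compound 4 (within the scatter), so this change is also flat on both cores: the same change on two cores in the liver carboxylesterase 1 assay, no change at the digits printed (within the scatter) from compound 2 to compound 3 and no change at the digits printed (within the scatter) from compound 4 to compound 1, 1.0-fold (0.00 log units) apart, within the scatter of two such steps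

In a physicochemical assay for lipophilicity, measured as octanol-water partition, at pH 2 (on this read-out higher numbers stand for higher lipophilicity and lower numbers for lower lipophilicity), compound 2 gives 0.21 and compound 4 gives 0.11, and the change at the chain gives a number 0.10 log units lower from compound 2 to compound 4 (within the scatter), so that read-out does not separate the pair either.

All four compounds share one printed half-life in the liver carboxylesterase 1 assay, so the compounds shown do not reveal whether any change at these two places can move it. As far as these compounds go, the effect of a longer chain such as butoxy, or of a carboxylic acid in place of the ester, remains open.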